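The source may report more compounds than this note shows. Statements on the series, on what has been measured and on what is new or still open speak of the compounds shown alone.

Measured compounds:
- Compound 2 `COc1ccccc1-c1nc2ccccc2n1CCCN1CCC(c2cccc(NC(C)=O)c2)CC1`: 747 nM
- Compound 3 `CCc1ccc(-c2nc3ccccc3n2CCCN2CCC(c3cccc(NC(C)=O)c3)CC2)cc1`: 32 nM
- Compound 1 `CC(=O)Nc1cccc(C2CCN(CCn3c(-c4ccccc4)nc4ccccc43)CC2)c1`: 10000 nM

In an assay for displacement of a labelled ligand from melanin-concentrating hormone receptor 1 (Homo sapiens), read by fluorescence (on this read-out higher numbers stand for weaker inhibition and lower numbers for stronger inhibition), compound 2 stands second highest of the three numbers; compound 3 is far lower, while compound 1, which also carries a shorter chain, lies well above it. Compound 4 `CC(=O)Nc1cccc(C2CCN(CCCn3c(-c4ccc(Cl)cc4Cl)nc4ccccc43)CC2)c1` differs from compound 2 in one place: 2,4-dichlorophenyl in place of 2-methoxyphenyl on an aromatic carbon. Among the compounds with values here, the one step that bears on this change is a 23-fold lower number from compound 2 to compound 3 (1.37 log units; beyond the scatter), where the 2-methoxyphenyl was likewise exchanged, there for 4-ethylphenyl. A drop in this assay is therefore expected for compound 4, though smaller than that step, since a substituent remains on the same position as the methoxy. The estimate for compound 4 is 100 nM, range 25 nM to 400 nM, an expected step of a 7.5-fold lower number from compound 2 to compound 4 (0.87 log units; beyond the scatter).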

Compound 4, half-maximal inhibitory concentration: 3 nM
Compound 4: middle estimate off by 33-fold (1.52 log units), on the high side; measured number outside the range, below it.
By their numbers in this assay, from the lowest: compound 4; then compound 3; then compound 2; then compound 1.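

In this assay, the 2,4-dichlorophenyl group on this carbon gives a 250-fold lower number from compound 2 to compound 4 (2.40 log units; beyond the scatter) and is a far larger change than the earlier exchange showed. It also improves on the 4-ethylphenyl group, with an 11-fold lower number from compound 3 to compound 4 (1.03 log units; beyond the scatter) as the step. The number at this carbon can therefore fall well past that of compound 3, even with a group that, like the 2-methoxyphenyl, is substituted at its 2 position. No measurement at hand explains the size of this gain. The compounds shown leave open what a 2-chlorophenyl or a 4-chlorophenyl group would give here, and so whether one chlorine or both account for the drop.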